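Pyridin-2-yl for phenyl on a fused ring core

This account rests on a few compounds, and the source may have more. Where it says the series, first, only, none or still open, it means among the compounds named here.

Compound 1, `CNC(=O)c1cc(C(=O)N[C@H]2[C@@H]3COC[C@@H]32)cc2c1OC[C@H]2c1ccccc1`: >= 165 ug/mL
Compound 2, `CC[C@@]1(c2ccccc2)COc2c(C(=O)NC)cc(C(=O)N[C@H]3[C@@H]4COC[C@@H]43)cc21`: >= 152 ug/mL

Of the compounds shown here, two have been measured in a physicochemical assay for solubility; on this read-out higher numbers stand for higher solubility and lower numbers for lower solubility. Compound 1 is `CNC(=O)c1cc(C(=O)N[C@H]2[C@@H]3COC[C@@H]32)cc2c1OC[C@H]2c1ccccc1`. In this assay compound 1 gives >= 165 ug/mL, which is a limit of the assay and not a number. Compound 2 is `CC[C@@]1(c2ccccc2)COc2c(C(=O)NC)cc(C(=O)N[C@H]3[C@@H]4COC[C@@H]43)cc21`. In this assay compound 2 gives >= 152 ug/mL, also a limit. Among the compounds with values here, compound 1 therefore stands only at a limit, and the one further value shown is itself a limit, so the two values show nothing more than that both sit at the high end of the read-out, as the limit of >= 165 ug/mL in this assay, at which 1 of the 2 values shown sits, and the limit of >= 152 ug/mL in this assay, at which 1 of the 2 values shown sits, record.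

Compound 3 is `CNC(=O)c1cc(C(=O)N[C@H]2[C@@H]3COC[C@@H]32)cc2c1OC[C@H]2c1ccccn1`. pyridin-2-yl in place of phenyl on a saturated ring carbon

Within the data shown here, no step between measured compounds is available to calibrate this change. In this assay the step is expected to be none beyond the scatter, with the value staying at or past the limit. The expected step is a step that the limit leaves unreadable from compound 1 to compound 3, within the usual scatter. Compound 3 is accordingly expected to give 200 ug/mL, with a range from 120 ug/mL to 400 ug/mL.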

Compound 3, solubility: >= 158 ug/mL
Compound 3 was reported as a limit; the forecaster's own chance of this, stated with the estimate: 70%; the middle value is on the limit's open side.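

In this assay compound 3 gives >= 158 ug/mL, which is a limit of the assay and not a number. Compound 1 also stands at a limit, so no step can be read for pyridin-2-yl in place of phenyl between compound 1 and compound 3. The compounds shown leave open how far past its limit each of these two compounds lies in this assay.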